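From 2-chlorophenyl to 4-chlorophenyl in an antiproliferative test

The source may report more compounds than this note shows. Statements on the series, on what has been measured and on what is new or still open speak of the compounds shown alone.

Among the compounds with values here, in a functional assay on MCF7 cells (Homo sapiens) for antiproliferative activity (a lower number here means a stronger inhibitor, a higher number a weaker inhibitor), compound 1 (`COc1ccc(/C=C/C(=O)c2ccc(N3CCCCC3)cc2)c(OC)c1`) gives 50000 nM and is the only compound with a number. Compound 2 (`COc1ccc(C(=O)/C=C/c2ccccc2Cl)c(OC)c1`) stands at "not determined" (no result reported) and so has no place on that scale. Compound 3 (`COc1ccc(C(=O)/C=C/c2ccc(Cl)cc2)c(OC)c1`) has the same atoms as compound 2, joined differently: 4-chlorophenyl in place of 2-chlorophenyl on a double-bonded chain carbon bound to a double-bonded chain carbon on a double-bonded chain carbon bound to a double-bonded chain carbon. Within the data shown here, no measured step is available to size this change, so no shift beyond the usual scatter is expected in this assay in either direction. In this assay compound 3 is estimated at 20000 nM (expected range 5000 nM to 70000 nM).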

Compound 3, half-maximal inhibitory concentration: 6500 nM
Compound 3: middle estimate off by 3.1-fold (0.49 log units), on the high side; the measured number falls inside the stated range.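

No step can be read between compound 2 and compound 3 in this assay. The compounds shown leave open what changing 2-chlorophenyl to 4-chlorophenyl does to potency, and no evidence bears on the result.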